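The source may report more compounds than this note shows. Statements on the series, on what has been measured and on what is new or still open speak of the compounds shown alone.

Compound 3 `CCc1nnsc1CO/N=C/c1c(C)nn(C)c1Cl` stands at the edge of what a functional assay on SGC-7901 cells (Homo sapiens) for inhibition, read by MTT assay, with a stated time of 48 h (a lower number here means a stronger inhibitor, a higher number a weaker inhibitor), can report. In this assay compound 3 gives > 50000 nM, which is a limit rather than a number, the one described as the limit of > 50000 nM in this assay, at which 1 of the 3 values shown sits. Compound 4 `CCCc1nnsc1CO/N=C/c1c(C)nn(C)c1Cl` differs from it by methyl in place of hydrogen on a saturated chain carbon, two bonds along the chain from an aromatic carbon. Among the measured compounds shown here, the only single-change step measured here is a different one: between compound 1 `CCCc1nnsc1CO/N=C/c1c(C)nn(C)c1Oc1ccccc1Cl` and compound 2 `CCCc1nnsc1CO/N=C/c1c(C)nn(C)c1Oc1ccccc1C` there is a 1.1-fold lower number from compound 1 to compound 2 (0.03 log units; within the scatter). In this assay, for the measured compounds named here, compound 1 gives 17600 nM and compound 2 gives 16300 nM; both carry the propyl chain of compound 4 but differ from compound 3 in more than one place, so no measured step bears directly on the change at hand. Compound 4 is therefore expected to remain close to the limit, an expected step of a number no higher from compound 3 to compound 4 (the limit leaves the size open). Compound 4 is estimated at 50000 nM, with a range from 15000 nM to 150000 nM.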

Compound 4, half-maximal inhibitory concentration: > 50000 nM
Compound 4 ended at the assay's limit (the forecaster's own chance of this, stated with the estimate: 60%); the middle value sits exactly at the limit.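

In this assay, the change from ethyl to propyl cannot be read, as compound 3 and compound 4 both give only a limit, and with chloro on the aromatic carbon the propyl chain leaves the value at that limit: the limit of > 50000 nM in this assay, at which 2 of the 4 values shown sit.

The propyl series does give a reading at the other site: chloro in place of 2-methylphenoxy gives an at least 3.0-fold higher number from compound 2 to compound 4 (0.48 log units; beyond the scatter), and chloro in place of 2-chlorophenoxy gives an at least 2.8-fold higher number from compound 1 to compound 4 (0.45 log units; beyond the scatter).

Going by these compounds, whether a butyl chain, or an amine in place of chloro on that aromatic carbon, would give a readable number stays open. So does the effect of ethyl to propyl in compounds carrying 2-chlorophenoxy.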